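Chain shortening and cell viability in three analogues

The compounds below may be only part of what the source reports. "The series", "measured", "known", "first", "only" and "open" are said of these compounds alone.

Measured compounds:
compound 1 `CCCCCCCCCCCO[C@@H]1[C@@H](N)[C@@H](O[C@H]2[C@H](O)[C@@H](OCCCCCCC)[C@H](N)C[C@@H]2N)O[C@H](CN)[C@H]1O`: 39.1%
compound 2 `CCCCCCCCCO[C@@H]1[C@@H](N)[C@@H](O[C@H]2[C@H](O)[C@@H](O)[C@H](N)C[C@@H]2N)O[C@H](CN)[C@H]1OCCCCCCCCC`: 48.6%
compound 3 `CCCCCCCCCCCO[C@@H]1[C@@H](O)[C@H](O[C@H]2O[C@H](CN)[C@@H](O)[C@H](O)[C@H]2N)[C@@H](N)C[C@H]1N`: 83.4%

In an ADME assay on J774 cells (Mus musculus) for cytotoxicity, read by MTT assay, with a stated time of 24 h, tested at 30 uM (a lower number here means a stronger effect, a higher number a weaker effect of the compound at the concentration tested), compound 3 stands highest of the three numbers, so it shows the weakest effect at the tested concentration; compound 2 is nearest, a number beyond the scatter below it, and compound 1 is furthest, also beyond the scatter. Compound 4 `CCCCCCCO[C@@H]1[C@@H](O)[C@H](O[C@H]2O[C@H](CN)[C@@H](O)[C@H](O)[C@H]2N)[C@@H](N)C[C@H]1N` has not yet been measured. It differs from compound 3 in one place: hydrogen in place of butyl on a saturated chain carbon, seven bonds along the chain from an oxygen on a saturated carbon. Going by the values given here, no step between two measured compounds isolates this change, so the expectation rests on compound 3 alone. The expected step of a number 6.6 percentage points higher from compound 3 to compound 4 (within the scatter) is small, upward at most, and may lie within the scatter. For compound 4 the estimate is 90%, expected between 76% and 100%.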

Compound 4, a percentage reported as activity, at one concentration (the size of the read-out at that concentration, not a potency): 71.3%
Compound 4: the middle estimate sits 18.7 percentage points above what was measured, and the stated range ends above it.
By their numbers in this assay, from the lowest: compounds 1 and 2 (each within the scatter of the next); then compound 4; then compound 3.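

In this assay the chain position gives its first readable step: hydrogen in place of butyl gives a number 12.1 percentage points lower from compound 3 to compound 4 (beyond the scatter) and so the heptyl compound shows the stronger effect at the concentration tested. Hydrogen in place of undecyl on an oxygen on a saturated carbon gives a number 32.2 percentage points higher from compound 1 to compound 4 (beyond the scatter) as a large step in the opposite direction, so the two chain changes do not read alike. Nothing available explains either step.

Two steps cannot fix a trend with chain length. On these data alone, whether a propyl chain, a longer chain than undecyl or an amine at the chain end would follow either step remains open.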